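From propargyl ether to 2-fluorobenzyl ether

A few compounds are considered here, and "the series" means these few. Any claim that something is new, unique, unknown or untested is made for them only; others in the source may bear on it.

Compound 1 `C#CCOc1ccc2c(=O)c(-c3cc(OC)c(OC)cc3OC)coc2c1` gives 4500 nM in a functional assay on B16 cells (Mus musculus) for antiproliferative activity, read by MTT assay, with a stated time of 24 h (on this read-out higher numbers stand for weaker inhibition and lower numbers for stronger inhibition), the lowest of the two numbers shown, though compound 2 `COc1ccc2c(=O)c(-c3cc(OC)c(OC)cc3OC)coc2c1`, at 5200 nM, sits within the scatter of it (a 1.2-fold higher number from compound 1 to compound 2 (0.06 log units; within the scatter)). Compound 3 `COc1cccc(C(=O)Oc2ccc3c(=O)c(-c4cc(OC)c(OC)cc4OC)coc3c2)c1` reaches only a limit of the assay, > 10000 nM. The step of an at least 2.2-fold higher number from compound 1 to compound 3 (0.34 log units; beyond the scatter) is the only one in which the propargyl group gives way to something larger, and it runs toward weaker inhibition; the step of an at least 1.9-fold higher number from compound 2 to compound 3 (0.28 log units; that floor lies within the scatter) points the same way without clearing the scatter. Compound 4 `COc1cc(OC)c(-c2coc3cc(OCc4ccccc4F)ccc3c2=O)cc1OC` differs from compound 1 by 2-fluorophenyl in place of ethynyl on a saturated chain carbon bound to an oxygen on an aromatic ring. Because the step of an at least 2.2-fold higher number from compound 1 to compound 3 (0.34 log units; beyond the scatter) ran weaker, compound 4 is expected to give 7500 nM (range 3000 nM to 16000 nM), an estimated step of a 1.7-fold higher number from compound 1 to compound 4 (0.22 log units; within the scatter).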

Compound 4, half-maximal inhibitory concentration: 1610 nM
Estimate against measurement, compound 4: 4.7-fold (0.67 log units) above, and the stated range ends above it.
By their numbers in this assay, from the lowest: compound 4; then compounds 1 and 2 (each within the scatter of the next). At a limit, above all of these: compound 3.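

At this position, on a saturated chain carbon bound to an oxygen on an aromatic ring, 2-fluorophenyl gives the first step toward stronger inhibition in this assay that clears the scatter: a 2.8-fold lower number from compound 1 to compound 4 (0.45 log units; beyond the scatter) and a 3.2-fold lower number from compound 2 to compound 4 (0.51 log units; beyond the scatter). Going by these compounds alone, a larger group here therefore need not weaken inhibition, as the one earlier change beyond the scatter had. The step of an at least 6.2-fold lower number from compound 3 to compound 4 (0.79 log units; beyond the scatter) is only a floor, compound 3 standing at a limit: the limit of > 10000 nM in this assay, at which 1 of the 4 values shown sits.

The compounds shown leave open whether the fluorine or the aromatic ring carries this step, which an unsubstituted benzyl would address. They also leave open how a chain ending in an amine would behave here.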